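The source may report more compounds than this note shows. Statements on the series, on what has been measured and on what is new or still open speak of the compounds shown alone.

Measured so far:
compound 1, `O=Cc1ccc(-c2cn3ccnc3c(-c3ccc4ncn(C5CCCCC5)c4c3)n2)cc1`, 51.2%
compound 2, `FC(F)(F)c1cccc(-c2cn3ccnc3c(-c3ccc4ncn(C5CCCCC5)c4c3)n2)c1`, 21.8%
compound 3, `CCc1ccc(-c2cn3ccnc3c(-c3ccc4ncn(Cc5ccccc5)c4c3)n2)cc1`, 43.2%

In a functional assay on MDA-MB-231 cells (Homo sapiens) for inhibition, read by sulforhodamine B assay, with a stated time of 48 h, tested at 10 uM (on this read-out lower numbers stand for less inhibition and higher numbers for more inhibition at the one concentration tested (going by the name of the read-out)), compound 3 gives 43.2%, the second highest of the three numbers. Its nearest neighbour is compound 1, which in this assay gives 51.2%, a gap within the scatter. Furthest away is compound 2, which gives 21.8%, a gap beyond the scatter.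

Compound 4, `O=Cc1ccc(-c2cn3ccnc3c(-c3ccc4ncn(Cc5ccccc5)c4c3)n2)cc1`, differs from compound 3 in one place: formyl in place of ethyl on an aromatic carbon. Going by the values given here, only one step has been measured, a number 29.4 percentage points lower from compound 1 to compound 2 (beyond the scatter), and it concerns 3-(trifluoromethyl)phenyl in place of 4-formylphenyl rather than ethyl against formyl, so it bears on the present change only loosely. Compound 1 carries the formyl that enters here, but it differs from compound 3 in two places, so only the two values can be set side by side, and they lie within the scatter. No step beyond the scatter is therefore expected in this assay. Compound 4 is expected to give 47%, with a range from 32% to 62%. The implied step, a number 3.8 percentage points higher from compound 3 to compound 4 (within the scatter), is expected to remain within the scatter.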

Compound 4, a percentage reported as inhibition, at one concentration (the size of the read-out at that concentration, not a potency): 51.2%
Compound 4: middle estimate off by 4.2 percentage points, on the low side, and the stated range covers the measured number.
By their numbers in this assay, from the lowest: compound 2; then compounds 3, 1 and 4 (each within the scatter of the next).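

In this assay, formyl in place of ethyl on an aromatic carbon, para to a large group, gives a number 8 percentage points higher from compound 3 to compound 4 (within the scatter), so with benzyl on the aromatic nitrogen the two groups cannot be told apart at this position. Benzyl in place of cyclohexyl on that nitrogen, with 4-formylphenyl held fixed, gives no change at the digits printed from compound 1 to compound 4 (within the scatter), which is the first direct reading of this change and likewise separates neither group. Nothing available here explains either result.

Going by these compounds, it remains open whether an amine, a carboxylic acid or a longer chain at the same place would stay within the scatter of formyl and ethyl. On these data alone, it is also open how a smaller or a longer group than benzyl or cyclohexyl would read on the aromatic nitrogen.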